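Shortening the acid chain on the aminopyridine thioether

This account rests on a few compounds, and the source may have more. Where it says the series, first, only, none or still open, it means among the compounds named here.

Two compounds share a core in which a naphthalene nitrile is joined through a nitrogen to a pyridine bearing a sulfur-linked acid chain. Compound 1 `CN(c1cnccc1SCCCCC(=O)O)c1ccc(C#N)c2ccccc12` carries a methyl on that nitrogen and gives 3580 nM in an assay on HEK293 cells for inhibition of solute carrier family 22 member 12 (Homo sapiens), read by scintillation counting, with stated times of 30 min and 15 min; on this read-out lower numbers stand for stronger inhibition and higher numbers for weaker inhibition. Compound 2 `N#Cc1ccc(Nc2cnccc2SCCCCCCC(=O)O)c2ccccc12` has an unsubstituted amine and a longer chain, and in this assay compound 2 gives 5750 nM. The two values lie within the scatter of one another, so neither is set apart on the numbers shown.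

Compound 3 `N#Cc1ccc(Nc2cnccc2SCCCCC(=O)O)c2ccccc12` keeps the unsubstituted amine of compound 2 and shortens the chain: carboxy in place of 2-carboxyethyl on a saturated chain carbon, four bonds along the chain from a sulfur. Within the data shown here, no measured pair isolates this change, so the expectation rests on compound 1, whose chain has the same length and whose value 3580 nM sits close to that of compound 2. Compound 3 is therefore expected to show a step of a 1.4-fold lower number from compound 2 to compound 3 (0.16 log units; within the scatter), not beyond the scatter, and its estimated value in this assay is 4000 nM, within a range of 1500 nM to 11000 nM.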

Compound 3, half-maximal inhibitory concentration: 2280 nM
The estimate for compound 3 lay 1.8-fold (0.24 log units) above the measured number; low and high end bracket the measured number.
By their numbers in this assay, from the lowest: compounds 3, 1 and 2 (each within the scatter of the next, the first and the last beyond it).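

In this assay, shortening the acid chain now has a measured effect of its own: with the unsubstituted amine held fixed, carboxy in place of 2-carboxyethyl gives a 2.5-fold lower number from compound 2 to compound 3 (0.40 log units; beyond the scatter), a modest step. Hydrogen in place of methyl on the nitrogen gives a 1.6-fold lower number from compound 1 to compound 3 (0.20 log units; within the scatter), so at this chain length the two are not told apart on these numbers. Nothing shown here accounts for either step.

The compounds shown leave open how the number moves with a still shorter chain, such as one ending in carboxymethyl, or with an amide in place of the carboxylic acid. They also leave open whether a larger group on the nitrogen, such as ethyl, would separate from hydrogen or methyl.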